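The compounds below may be only part of what the source reports. "The series", "measured", "known", "first", "only" and "open" are said of these compounds alone.

Compound 3, with the structure `Cc1nc2ccc(CN(CC(N)=O)c3ccc(C(=O)N[C@@H](CCC(=O)O)C(=O)O)c(F)c3)cc2c(=O)[nH]1`, gives 800 nM in a functional assay on L1210 cells (Mus musculus) for inhibition; on this read-out lower numbers stand for stronger inhibition and higher numbers for weaker inhibition. For the measured compounds named here, that puts it second highest of the three numbers measured so far: nearest to it stands compound 1, `Cc1nc2ccc(CN(CCN)c3ccc(C(=O)N[C@@H](CCC(=O)O)C(=O)O)c(F)c3)cc2c(=O)[nH]1`, at 2700 nM, and furthest from it compound 2, `CCN(Cc1ccc2nc(C)[nH]c(=O)c2c1)c1ccc(C(=O)N[C@@H](CCC(=O)O)C(=O)O)cc1F`, at 86 nM. The unmeasured compound 4, `CCN(Cc1ccc2nc(C)[nH]c(=O)c2c1)c1ccc(C(=O)N[C@@H](CCC(=O)O)C(=O)O)c(F)c1`, differs from compound 3 in one place: methyl in place of carbamoyl on a saturated chain carbon bound to a nitrogen on an aromatic ring.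

Going by the values given here, only one measured step speaks to this change. The step of a 3.4-fold lower number from compound 1 to compound 3 (0.53 log units; beyond the scatter) trimmed a polar group on the same chain carbon bound to the nitrogen on the aromatic ring, and the number fell. Compound 4 takes that trimming further, leaving a plain ethyl on that nitrogen. Among the compounds with values here, compound 2 carries the same ethyl, with its fluorine placed differently on the ring, and its value of 86 nM lies well below that of compound 3; no step between compound 2 and compound 4 is available, so that comparison remains only indicative.

Compound 4 is therefore expected to fall further than compound 3, as a step of a 5.3-fold lower number from compound 3 to compound 4 (0.73 log units; beyond the scatter) beyond the scatter. The estimate for compound 4 in this assay is 150 nM, with a range from 40 nM to 500 nM.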

Compound 4, half-maximal inhibitory concentration: 65 nM
Beside the measured number, compound 4's estimate is 2.3-fold (0.36 log units) above it, and the stated range covers the measured number.
By their numbers in this assay, from the lowest: compounds 4 and 2 (each within the scatter of the next); then compound 3; then compound 1.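

In this assay, the carbamoyl-to-methyl change gives a 12-fold lower number from compound 3 to compound 4 (1.09 log units; beyond the scatter) and so counts as a large step, whereas the earlier swap of aminomethyl for carbamoyl gave only the modest 3.4-fold lower number from compound 1 to compound 3 (0.53 log units; beyond the scatter). For the compounds shown here, until now, the only comparison at this position was between two nitrogen-bearing groups, and the new result shows that the number on this read-out keeps falling when the chain ends in a plain methyl, with no hydrogen-bond donor or acceptor left in the group. Taking the amino group away altogether gives a 42-fold lower number from compound 1 to compound 4 (1.62 log units; beyond the scatter), so among compounds 1, 3 and 4 the order runs from aminomethyl through carbamoyl to methyl, and none of these three goes against it. No measurement shown gives a reason for this fall.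

The compounds shown leave open whether the heavy atoms of the carbamoyl group or its donor and acceptor count matter more, since the step changes both at once. They also leave open how a hydroxyl group, a nitrile or a longer chain such as propyl on this saturated chain carbon would compare with the ethyl of compound 4.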